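Swapping the pentyl chain for 1-phenylethyl

The source may report more compounds than this note shows. Statements on the series, on what has been measured and on what is new or still open speak of the compounds shown alone.

Measured so far:
compound 1 `N/C(=N\C(=O)NC1CCCCC1)Nc1cccc(-c2csc(N)n2)c1`: 4470 nM
compound 2 `CCCCCNC(=O)/N=C(\N)NCCCc1sc(N)nc1C`: 4.47 nM
compound 3 `CCCCCCNC(=O)/N=C(\N)NC1CCc2nc(N)sc2C1`: 1120 nM

In an assay on membranes from Sf9 cells for displacement of a labelled ligand from histamine H2 receptor (Homo sapiens), read by scintillation counting, with a stated time of 60 min (on this read-out higher numbers stand for weaker inhibition and lower numbers for stronger inhibition), compound 2 gives 4.47 nM, the lowest of the three numbers and so the strongest inhibitor of the set. The nearest number belongs to compound 3, which in this assay gives 1120 nM, a gap far beyond the usual scatter. Compound 1 stands furthest away and in this assay gives 4470 nM. No two of these three compounds differ in only one place, so none of these gaps can be tied to a single structural change.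

Compound 4 `Cc1nc(N)sc1CCCN/C(N)=N/C(=O)N[C@H](C)c1ccccc1` has not yet been measured. It differs from compound 2 in one place:

1-phenylethyl in place of pentyl on an amide-type nitrogen

Nothing measured here separates the effect of this one change from other differences, so the expectation rests on compound 2 alone. The step from compound 2 to compound 4 is expected to be a 2.2-fold higher number from compound 2 to compound 4 (0.35 log units; beyond the scatter), a modest weakening that may still fall within the scatter. Compound 4 is therefore estimated to give 10 nM in this assay, within a range from 2 nM to 60 nM.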

Compound 4, inhibition constant: 17.8 nM
Beside the measured number, compound 4's estimate is 1.8-fold (0.25 log units) below it, within the range that was stated.
By their numbers in this assay, from the lowest: compound 2; then compound 4; then compound 3; then compound 1.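

In this assay, putting 1-phenylethyl in place of pentyl on the amide-type nitrogen gives a 4.0-fold higher number from compound 2 to compound 4 (0.60 log units; beyond the scatter), a modest step and the first in this set that can be tied to a single structural change. It shows that this position can take a group of 8 heavy atoms with a six-membered aromatic ring of carbon only and a defined stereocentre in place of a ringless chain of 5 carbons, with compound 4 still reading 17.8 nM in this assay. No measurement shown here explains the size of this step.

The swap brings in the ring, the stereocentre and the extra heavy atoms all at once, so the compounds shown leave open how much of the step belongs to each. Benzyl on the same nitrogen would keep the ring without the stereocentre, and the mirror-image form of 1-phenylethyl would change only the stereocentre, so each would separate part of this step.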